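Adding a Hydroxy Group to Compound 2

The source may hold more compounds than are shown below. What is called first, only, known or untested is meant among the compounds shown, and "the series" means these compounds.

In a functional assay on A549 cells (Homo sapiens) for cytotoxicity, read by MTT assay, with a stated time of 6 days (a higher number here means that more compound is needed for the effect, a lower number that less compound is needed), compound 1 (`O=c1cc(-c2ccc([N+](=O)[O-])cc2)oc2ccc(O)cc12`) gives 5.07 ug/mL as a measured number. Compound 2 (`COc1cc(-c2cc(=O)c3ccc(O)cc3o2)cc(OC)c1OC`) stands at > 25 ug/mL in this assay and that is a limit of the assay, not a number. Compound 3 (`COc1cc(-c2cc(=O)c3ccc(O)c(O)c3o2)cc(OC)c1OC`) differs from compound 2 by a single change (hydroxy in place of hydrogen on an aromatic carbon), hydroxy in place of hydrogen on an aromatic carbon, ortho to a hydroxy group. Going by the values given here, no measured pair shows this change, so only a modest shift in this assay toward less compound needed is expected, and compound 3 may also return only a limit. The estimated shift (an at least 1.3-fold lower number from compound 2 to compound 3 (0.14 log units; that floor lies within the scatter)) is therefore small. For compound 3 the expected value is 18 ug/mL with an estimated range (7 ug/mL to 40 ug/mL) around it.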

Compound 3, concentration for half-maximal effect: 5.27 ug/mL
Beside the measured number, compound 3's estimate is 3.4-fold (0.53 log units) above it; the measured number lies below the stated range.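

Hydroxy in place of hydrogen on an aromatic carbon, ortho to a hydroxy group, gives in this assay the first step read at this position: an at least 4.7-fold lower number from compound 2 to compound 3 (0.67 log units; beyond the scatter). The change turns a limit into a measured number for compound 3. Compound 2 stands at > 25 ug/mL, which is a limit of the assay and not a number, so the step has a floor but no known size: the limit of > 25 ug/mL in this assay, at which 1 of the 3 values shown sits.

From the compounds shown here alone, whether an amine or a fluorine at this position would give a similar step remains open. So does whether the same change would carry over to the core of compound 1.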